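A few compounds are considered here, and "the series" means these few. Any claim that something is new, unique, unknown or untested is made for them only; others in the source may bear on it.

In an ADME assay on the whole organism (strain CD-1) for metabolic stability, with Mus musculus as the target, at a dose of 3 mg/kg by the intravenous route (on this read-out lower numbers stand for a shorter-lived compound and higher numbers for a longer-lived compound), compound 1 (`CC(CCCCOc1ccccc1CN(C)C(=O)c1ccc(-c2ccco2)cc1)C(=O)O`) gives 2.8 h, compound 2 (`C[C@H](CCCOc1ccccc1CN(C)C(=O)c1ccc(-c2ccco2)cc1)CC(=O)O`) gives 3.9 h and compound 3 (`C[C@@H](CCCOc1ccccc1CN(C)C(=O)c1ccc(-c2ccco2)cc1)CC(=O)O`) gives 2 h, so compound 3 stands level with the other two within the scatter. Compound 4 (`CN(Cc1ccccc1OCCC[C@@H]1C[C@@H]1C(=O)O)C(=O)c1ccc(-c2ccco2)cc1`) differs from it thus: 2-carboxycyclopropyl in place of 1-(carboxymethyl)ethyl on a saturated chain carbon, three bonds along the chain from an oxygen on an aromatic ring. The measured steps bear on this only indirectly, and none of them forms the three-membered ring. Moving the methyl-bearing chain carbon gave a 1.4-fold lower number from compound 1 to compound 3 (0.15 log units; within the scatter), while the fact that compounds 2 and 3 differ only in the configuration as drawn goes with a 2.0-fold lower number from compound 2 to compound 3 (0.29 log units; within the scatter). Since both steps stay within the scatter, no step beyond it is expected in this assay, in either direction. The expected step is a 1.3-fold higher number from compound 3 to compound 4 (0.10 log units; within the scatter). For compound 4 the estimated half-life is 2.5 h, with an expected range of 1.2 h to 5 h.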

Compound 4, half-life: 2.7 h
Estimate against measurement, compound 4: 1.1-fold (0.03 log units) below, within the range that was stated.
By their numbers in this assay, from the lowest: compounds 3, 4, 1 and 2 (each within the scatter of the next).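

The 2-carboxycyclopropyl group, with its three-membered carbon ring, stands level with both open chains at this position, three bonds along the chain from an oxygen on an aromatic ring (a 1.4-fold higher number from compound 3 to compound 4 (0.13 log units; within the scatter)) (a 1.4-fold lower number from compound 2 to compound 4 (0.16 log units; within the scatter)) (a 1.0-fold lower number from compound 1 to compound 4 (0.02 log units; within the scatter)). Thus, in this assay, tying the chain into this ring and adding a second defined stereocentre gives no step beyond the scatter. Nothing shown gives a cause for this result.

Still open, from the compounds shown here alone, is how the half-life responds to the other configurations of the 2-carboxycyclopropyl group. A cyclobutane ring at this position, or an amide in place of the carboxylic acid, is also untested among the compounds shown.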